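The source may report more compounds than this note shows. Statements on the series, on what has been measured and on what is new or still open speak of the compounds shown alone.

Three measured compounds share a core in which a phenyl sulfonamide is linked through an amide to a varying aromatic group. Compound 1 `O=C(Nc1ccc(S(=O)(=O)Nc2ccccc2)cc1)c1cc2ccccc2oc1=O` gives 53% in a functional assay on HEK293 cells for agonist activity at probable G-protein coupled receptor 27 (Homo sapiens), read by a luciferase reporter and beta-arrestin recruitment, with a stated time of 10 min; a higher number here means a larger maximal response, a lower number a smaller maximal response; compound 3 `O=C(Nc1ccc(S(=O)(=O)Nc2cccc(Cl)c2)cc1)c1ccc(Cl)cc1Cl` gives 40%. Compound 2 `O=C(Nc1ccc(S(=O)(=O)Nc2ccccc2)cc1)c1ccc(Br)cc1F` gives 67%, the highest of the three, standing above compound 1 and compound 3 by more than the usual scatter.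

Compound 4 `O=C(Nc1ccc(S(=O)(=O)Nc2ccccc2)cc1)c1ccc(Cl)nc1F` has not yet been measured. It differs from compound 2 in one place: 6-chloro-2-fluoropyridin-3-yl in place of 4-bromo-2-fluorophenyl on a carbonyl carbon. Among the compounds with values here, no measured pair shows what such a change does here, so the expected step from compound 2 to compound 4, a number 7 percentage points lower from compound 2 to compound 4 (within the scatter), is estimated to be small and within the scatter. Compound 4 is therefore expected to give about 60% in this assay, somewhere between 40% and 80%.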

Compound 4, largest response reached (Emax), in percent of the reference or control that the assay uses: 78%
Compound 4: middle estimate off by 18 percentage points, on the low side; low and high end bracket the measured number.
By their numbers in this assay, from the lowest: compound 3; then compound 1; then compound 2; then compound 4.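

Putting 6-chloro-2-fluoropyridin-3-yl in place of 4-bromo-2-fluorophenyl on the carbonyl carbon gives a number 11 percentage points higher from compound 2 to compound 4 (beyond the scatter) in this assay, so a ring with a hetero atom is accepted here without loss of response. This single change also shows that the aromatic group at this place can by itself move the maximal response beyond the usual scatter.

The compounds shown do not separate the ring nitrogen from the swap of bromine for chlorine, and they leave open how a ring bearing an amine or a carboxylic acid would respond here. Nothing available explains the gain.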